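This account rests on a few compounds, and the source may have more. Where it says the series, first, only, none or still open, it means among the compounds named here.

Measured so far in an ADME assay on S9 fraction from liver (Rattus norvegicus) for metabolic stability, read by LC-MS, using NADPH, with a stated time of 60 min, tested at 10 uM; on this read-out lower numbers stand for a less stable compound and higher numbers for a more stable compound:
Compound 1 `C[C@H](O)Cc1cc(-c2ccnc3[nH]nc(C(F)(F)F)c23)cc(C2(C#N)CC2)c1`: 37%
Compound 2 `N#CC1(c2cc(CC(O)C3CC3)cc(-c3ccnc4[nH]nc(C(F)(F)F)c34)c2)CC1`: 0%
Compound 3 `CC(=O)OCCc1cc(-c2ccnc3[nH]nc(C(F)(F)F)c23)cc(C2(C#N)CC2)c1`: 5%

The three compounds share a core and differ in one side chain. Compound 3, at 5%, stands far from the first compound, with a step of a number 32 percentage points lower from compound 1 to compound 3 (beyond the scatter). Its gap to the second compound is small, at a number 5 percentage points higher from compound 2 to compound 3 (within the scatter), so these two form the low end of the series.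

Compound 4 `COCCc1cc(-c2ccnc3[nH]nc(C(F)(F)F)c23)cc(C2(C#N)CC2)c1` turns 2-acetoxyethyl into 2-methoxyethyl, with methyl in place of acetyl on an oxygen on a saturated carbon.

Among the measured compounds shown here, no measured step makes this exchange. The nearest evidence is the set of steps at the same part of the side chain. One of them, a number 37 percentage points lower from compound 1 to compound 2 (beyond the scatter), shows that a change there can be large, while the small gap between compound 2 and compound 3 shows that it need not be. Compound 3 at 5% leaves little room downward, so a rise is thought likelier than a fall, though its size is poorly constrained. The expected step is modest: a number 13 percentage points higher from compound 3 to compound 4 (beyond the scatter). For compound 4 the estimated value is 18%, with an expected range from 3% to 45%.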

Compound 4, percent of the compound remaining: 90%
For compound 4 the middle estimate is 72 percentage points below the measured one; measured number above the stated range.
By their numbers in this assay, from the lowest: compounds 2 and 3 (each within the scatter of the next); then compound 1; then compound 4.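

In this assay, methyl in place of acetyl on an oxygen on a saturated carbon gives a number 85 percentage points higher from compound 3 to compound 4 (beyond the scatter) and so moves the compound from the low end of the series to its top. The earlier compounds had shown this side chain only as a place where the number fell from that of compound 1; now there is also a number 53 percentage points higher from compound 1 to compound 4 (beyond the scatter) as well as a number 90 percentage points higher from compound 2 to compound 4 (beyond the scatter), so the same position can carry a number well above any seen before, and compound 4 stands beyond the scatter from all three others. The step from 2-acetoxyethyl to 2-methoxyethyl also shows that what sits on this one oxygen can decide the outcome, yet nothing measured here explains why the exchange has so large an effect.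

The compounds shown leave open whether the result is particular to methyl or would hold for an ethyl group on the same oxygen, or for a longer chain between that oxygen and the core. They also leave open how an amine in place of the methoxy group would fare in this assay under the same conditions.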